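Same Swap, Second Core: Expected Tolerance of Compound 4

The source may report more compounds than this note shows. Statements on the series, on what has been measured and on what is new or still open speak of the compounds shown alone.

Three compounds have so far been measured in an ADME assay on MT4 cells (Homo sapiens) for cytotoxicity; a higher number here means that more compound is tolerated, a lower number that less compound is tolerated:

compound 1 `Cc1cc(C)cc(Cn2c(SCC(=O)Nc3ccccc3Br)nc3ccc(Cl)cc32)c1` gives 174000 nM
compound 2 `Cc1cc(C)cc(S(=O)(=O)n2c(SCC(=O)Nc3ccccc3Br)nc3ccc(Cl)cc32)c1` gives 145000 nM
compound 3 `Cc1cc(C)cc(Cn2c(SCC(=O)Nc3ccc(S(C)(=O)=O)cc3Cl)nc3ccccc32)c1` gives 106000 nM

Compound 1 and compound 2 share one core and differ in a single place: (3,5-dimethylphenyl)sulfonyl in place of 3,5-dimethylbenzyl on an aromatic nitrogen. That swap gave a 1.2-fold lower number from compound 1 to compound 2 (0.08 log units; within the scatter), so the two numbers are effectively the same.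

Compound 3 carries a different core; how it differs from compound 1 is not broken down here. Its number sits among the three without any step to another compound reaching beyond the scatter, so no ordering among them can be claimed.

Compound 4 `Cc1cc(C)cc(S(=O)(=O)n2c(SCC(=O)Nc3ccc(S(C)(=O)=O)cc3Cl)nc3ccccc32)c1` is the unmeasured partner of compound 3. It differs from compound 3 by (3,5-dimethylphenyl)sulfonyl in place of 3,5-dimethylbenzyl on an aromatic nitrogen, which is the same change that turned compound 1 into compound 2, made at the same kind of place on the second core.

Because that change gave a 1.2-fold lower number from compound 1 to compound 2 (0.08 log units; within the scatter) on the first core, the expectation is that compound 4 will stay close to compound 3, with an estimated step of a 1.2-fold lower number from compound 3 to compound 4 (0.07 log units; within the scatter). The estimate for compound 4 in this assay is 90000 nM, expected to fall between 45000 nM and 180000 nM. This rests on a single earlier example of the swap, so a larger move in either direction would not be surprising.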

Compound 4, half-maximal cytotoxic concentration: > 221000 nM
Compound 4: no number, only a limit; the forecaster's own chance of this, stated with the estimate: 15%; middle value at least 2.4-fold (0.39 log units) away from the limit.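

In this assay compound 4 gives > 221000 nM, which is a limit of the assay and not a number. On the core of compound 3, putting (3,5-dimethylphenyl)sulfonyl in place of 3,5-dimethylbenzyl on the aromatic nitrogen gave an at least 2.0-fold higher number from compound 3 to compound 4 (0.31 log units; beyond the scatter), so on this core the swap leaves the compound at least as well tolerated as before and moves the number beyond ordinary noise. This does not show that the swap behaves differently on the two cores, nor that its effect carries over unchanged from one core to the other, since the comparison stays unresolved: the same change on two cores in this assay, a 1.2-fold lower number (0.08 log units; within the scatter) from compound 1 to compound 2 and an at least 2.0-fold higher number (0.31 log units; beyond the scatter) from compound 3 to compound 4; the limit leaves it open whether they differ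

The compounds shown leave open how far the true number for compound 4 lies past its limit, and therefore how large this step really is. They also leave open how the number in this assay would respond on either core if an amine, a carboxylic acid or a longer chain stood on that aromatic nitrogen in place of 3,5-dimethylbenzyl or (3,5-dimethylphenyl)sulfonyl.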